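The compounds below may be only part of what the source reports. "The series", "measured", "known", "first", "only" and "open" are said of these compounds alone.

Compound 1 `COc1cc(-c2cc3nccc(-c4cc(OC)c(OC)c(OC)c4)n3n2)cc(OC)c1OC`: > 10000 nM
Compound 2 `COc1cc(-c2ccnc3cc(-c4cn(CO)c5ccccc45)nn23)cc(OC)c1OC`: 19 nM
Compound 3 `COc1cc(-c2ccnc3cc(-c4ccc(C)cc4)nn23)cc(OC)c1OC`: 47 nM

All three compounds were tested in a functional assay on MCF7 cells (Homo sapiens) for inhibition, read by CCK-8 assay, with a stated time of 48 h; on this read-out higher numbers stand for weaker inhibition and lower numbers for stronger inhibition. For compound 1, the entry > 10000 nM is a limit of the assay and not a number. That leaves two true numbers to compare. Compound 3, at 47 nM, has the higher of them, so it is the weaker inhibitor of the pair. Compound 2 gives 19 nM, a gap beyond the usual scatter of repeated measurements.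

Compound 4 `COc1cc(-c2ccnc3cc(-c4ccc(C(F)(F)F)cc4)nn23)cc(OC)c1OC` changes compound 3 in one place: trifluoromethyl in place of methyl on an aromatic carbon. Trifluoromethyl stands in place of methyl on an aromatic carbon, turning 4-methylphenyl into 4-(trifluoromethyl)phenyl. Among the compounds with values here, no two measured compounds differ in only one place, so the data offer no direct precedent for this change. The closest guide is that compound 2, with a quite different group in place of 4-methylphenyl, still gives 19 nM, not far from compound 3 at 47 nM. A modest rise in this assay is therefore expected, meaning somewhat weaker inhibition, slightly beyond the scatter. The estimated step is a 2.1-fold higher number from compound 3 to compound 4 (0.33 log units; beyond the scatter). For compound 4 the expected value is 100 nM, with an estimated range from 30 nM to 400 nM.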

Compound 4, half-maximal inhibitory concentration: 2440 nM
Compound 4: the middle estimate sits 24-fold (1.39 log units) below what was measured, outside the stated range (above it).
By their numbers in this assay, from the lowest: compound 2; then compound 3; then compound 4. At a limit, above all of these: compound 1.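

Within the data shown here, this is the first pair of compounds here that differ in only one place, and it shows that the substituent on this ring, para to a large group, strongly affects activity in this assay: the change to trifluoromethyl gives a 52-fold higher number from compound 3 to compound 4 (1.72 log units; beyond the scatter), which means much weaker inhibition. The swap looks small on paper, since one heavy atom becomes four while no ring, hydrogen-bond donor, hydrogen-bond acceptor or net charge enters or leaves, so a small edit at this spot can cost a great deal of activity. Compound 4 still gives a true number, so the size of this step can be read directly, and it has not reached the limit that applies to one other compound: the limit of > 10000 nM in this assay, at which 1 of the 4 values shown sits.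

A single step cannot show why trifluoromethyl does so much worse than methyl, or whether other replacements, such as a chlorine atom, an amine, a carboxylic acid or a longer chain, would fare better or worse at this place. It also leaves open whether the same change would cost as much on a different group attached to the shared core.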